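Shortening the acid chain: expected solubility of compound 3

This account rests on a few compounds, and the source may have more. Where it says the series, first, only, none or still open, it means among the compounds named here.

- compound 1 `O=C(O)CNC(=O)COc1ccc([C@H]2CC[C@]3(CC2)OOC2(O3)C3CC4CC(C3)CC2C4)cc1`: < 3.1 ug/mL (a limit)
- compound 2 `O=C(O)CCCCOc1ccc([C@H]2CC[C@]3(CC2)OOC2(O3)C3CC4CC(C3)CC2C4)cc1`: < 1.6 ug/mL (a limit)

In a physicochemical assay for solubility, read by nephelometry, measured as kinetic solubility, with a stated time of 30 min, at pH 2.0 (on this read-out lower numbers stand for lower solubility and higher numbers for higher solubility), compound 2 gives < 1.6 ug/mL, which is a limit and not a number. Compound 3 `O=C(O)CCCOc1ccc([C@H]2CC[C@]3(CC2)OOC2(O3)C3CC4CC(C3)CC2C4)cc1` differs from compound 2 by carboxy in place of carboxymethyl on a saturated chain carbon, three bonds along the chain from an oxygen on an aromatic ring. Going by the values given here, the only measured step bearing on this is a step that the two limits leave unreadable from compound 1 to compound 2, and it gives no readable size. The step expected is an at least 1.2-fold higher number from compound 2 to compound 3 (0.09 log units; that floor lies within the scatter), with no change beyond the scatter anticipated in either direction. Compound 3 is estimated at 2 ug/mL, within a range of 1 ug/mL to 6 ug/mL.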

Compound 3, solubility: < 1.6 ug/mL
Compound 3 gave a limit, no number; the forecaster's own chance of this, stated with the estimate: 80%; at least 1.2-fold (0.09 log units) between middle value and limit.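

In this assay, going by these compounds alone, compound 3 gives < 1.6 ug/mL, a limit and not a number, so no step among compound 1, compound 2 and compound 3 can be read. Going by these compounds, whether the length of the acid chain changes solubility at all stays open.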